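The source may hold more compounds than are shown below. What is called first, only, known or untested is meant among the compounds shown, and "the series" means these compounds.

In an assay on brain for binding affinity to Neuronal acetylcholine receptor; alpha4/beta2 (Rattus norvegicus), read by radioligand binding (on this read-out higher numbers stand for weaker inhibition and lower numbers for stronger inhibition), compound 1 `Cc1ccc(OC[C@@H]2CCN2)cn1` gives 0.057 nM. Compound 2 `COc1ccc(OC[C@@H]2CCN2)cn1` in this assay gives 1.3 nM, and the two are separated by a 23-fold higher number from compound 1 to compound 2 (1.36 log units; beyond the scatter). Compound 3 `Nc1cncc(OC[C@@H]2CCN2)c1` in this assay gives 0.082 nM, the second highest of the three numbers; against compound 1 it lies within the scatter, while against compound 2 it stands well beyond it.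

Compound 4 `CC(=O)NCc1cncc(OC[C@@H]2CCN2)c1` has not yet been measured in this assay. It differs from compound 3 in one place: acetamidomethyl in place of amino on an aromatic carbon. Among the measured compounds shown here, the only step that has been measured, a 23-fold higher number from compound 1 to compound 2 (1.36 log units; beyond the scatter), also exchanged one small group on an aromatic carbon of the shared core for another and moved the number a long way. The present change removes less and adds more than that step did, so some shift is expected, most likely toward a higher number, although one measured step gives no firm guide to how big it will be. The step of a 6.1-fold higher number from compound 3 to compound 4 (0.79 log units; beyond the scatter) is what the estimate means. Compound 4 is therefore expected to give 0.5 nM in this assay, with a range from 0.08 nM to 3 nM.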

Compound 4, inhibition constant: 0.54 nM
Compound 4: the middle estimate sits 1.1-fold (0.03 log units) below what was measured, within the range that was stated.
By their numbers in this assay, from the lowest: compounds 1 and 3 (each within the scatter of the next); then compound 4; then compound 2.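

In this assay, the step of a 6.6-fold higher number from compound 3 to compound 4 (0.82 log units; beyond the scatter) shows that this aromatic carbon, two atoms from the ring nitrogen, can carry a far larger group than amino, at a modest cost that still lies beyond the scatter. Amino has 1 heavy atom and acetamidomethyl has 5 heavy atoms and a double bond, yet both groups have the same counts of hydrogen-bond donors and acceptors and neither has a net charge, so this change adds bulk of atoms without altering those counts. No measurement here explains why the number rises.

On these data alone, whether an aminomethyl group, which would keep the added carbon without the acetyl part, would fall nearer compound 3 or nearer compound 4 remains open, so the shift cannot yet be divided between the two parts of the new group. Also open, as far as these compounds go, is how a longer amide chain, such as propionamidomethyl, or a carboxylic acid on this carbon would read, and whether the same exchange would cost as much on other aromatic carbons of the shared core.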